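Tertiary Amide Variant Against a Shared Cytotoxicity Ceiling

This account rests on a few compounds, and the source may have more. Where it says the series, first, only, none or still open, it means among the compounds named here.

Compound 1, `COc1cc(CNC(=O)c2nc3ccc(F)c(OCCc4ccc(C(=O)O)cc4)c3c(=O)[nH]2)ccc1F`, gives > 20000 nM in an ADME assay on HEK293 cells (Homo sapiens) for cytotoxicity, read by resazurin assay, with a stated time of 72 h (on this read-out lower numbers stand for higher toxicity in this test and higher numbers for lower toxicity in this test), a limit of the assay and not a number.
Compound 2, `Cc1cc(CNC(=O)c2nc3ccc(F)c(OCCc4ccc(C(=O)O)cc4)c3c(=O)[nH]2)ccc1F`, gives > 20000 nM in this assay, again a limit rather than a number.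
Compound 3, `CC(C)c1cccc(CNC(=O)c2nc3ccc(F)c(OCCc4ccc(C(=O)O)cc4)c3c(=O)[nH]2)c1`, gives > 20000 nM in this assay, likewise only a limit.

Compound 1 therefore stands at a limit only, and the same holds for the two compounds measured alongside it, since all three sit at the limit of > 20000 nM in this assay, at which 3 of the 3 values shown sit. The changes among them, a step that the two limits leave unreadable from compound 1 to compound 2, a step that the two limits leave unreadable from compound 1 to compound 3 and a step that the two limits leave unreadable from compound 2 to compound 3, cannot be read for size or direction because of the limit of > 20000 nM in this assay, at which 3 of the 3 values shown sit.

Compound 4, `CCc1cccc(CN(C)C(=O)c2nc3ccc(F)c(OCCc4ccc(C(=O)O)cc4)c3c(=O)[nH]2)c1`, differs from compound 1 in one place: (3-ethylbenzyl)(methyl)amino in place of (4-fluoro-3-methoxybenzyl)amino on a carbonyl carbon. Within the data shown here, no measured step bears on this change in a readable way, so no shift beyond the scatter can be foreseen in either direction. Compound 4 is expected to remain at the shared ceiling, with an expected step of a number no higher from compound 1 to compound 4 (the limit leaves the size open). The estimate for compound 4 is 20000 nM, expected to fall between 8000 nM and 40000 nM, and most probably it is expected to be reported only as a limit.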

Compound 4, half-maximal cytotoxic concentration: > 20000 nM
Compound 4: only a limit was reported; the forecaster's own chance of this, stated with the estimate: 80%; the middle value lies on the limit itself.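

Compound 4 gives > 20000 nM in this assay, again only a limit of the assay. Its steps from compound 1, compound 2 and compound 3 cannot be read because all four compounds share one limit: the limit of > 20000 nM in this assay, at which 4 of the 4 values shown sit.

The compounds shown leave open whether any of these changes alters the read-out in this assay.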